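Dropping one methyl from compound 1: what to expect

The source may hold more compounds than are shown below. What is called first, only, known or untested is meant among the compounds shown, and "the series" means these compounds.

Measured so far, in a functional assay for inhibition, with Rattus norvegicus as the target; on this read-out higher numbers stand for weaker inhibition and lower numbers for stronger inhibition:
- compound 1 `CCC(C)(C)/N=c1\c(O)c(O)\c1=N/Cc1c(C)cc(C)cc1C` gives 310 nM
- compound 2 `CCC(C)(C)/N=c1\c(O)c(O)\c1=N/Cc1c(Cl)cccc1Cl` gives 280 nM
- compound 3 `CCC(C)(C)/N=c1\c(O)c(O)\c1=N/Cc1ccc(C)cc1C` gives 530 nM

Among these three, compound 1 stands second highest; its nearest neighbour is compound 2, with a gap within the scatter, and compound 3 lies furthest from it, also within the scatter. Compound 4 `CCC(C)(C)/N=c1\c(O)c(O)\c1=N/Cc1c(C)cccc1C` is not yet measured. It differs from compound 1 by hydrogen in place of methyl on an aromatic carbon. Among the compounds with values here, only one measured step bears on this change: a 1.7-fold higher number from compound 1 to compound 3 (0.23 log units; within the scatter), where the same kind of removal of a methyl, though at another position on the same ring, produced a shift too small to stand apart from noise. On that basis the step in this assay is expected to be small and, if anything, towards a slightly higher number, so that a 1.4-fold higher number from compound 1 to compound 4 (0.13 log units; within the scatter) is the estimated outcome. Compound 4 is therefore expected to give about 420 nM, with a plausible range from 200 nM to 900 nM.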

Compound 4, half-maximal inhibitory concentration: 830 nM
The estimate for compound 4 lay 2.0-fold (0.30 log units) below the measured number; the measured number falls inside the stated range.
By their numbers in this assay, from the lowest: compounds 2, 1, 3 and 4 (each within the scatter of the next, the first and the last beyond it).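

In this assay, the methyl para to a large group and meta to two methyl groups proves to count: replacing it with hydrogen gives a modest step beyond the scatter (a 2.7-fold higher number from compound 1 to compound 4 (0.43 log units; beyond the scatter)). Within the data shown here, the only earlier step of this kind, taken at another position on the same ring, stayed within the scatter (a 1.7-fold higher number from compound 1 to compound 3 (0.23 log units; within the scatter)), so losing a methyl from this ring does not read the same at each position. Nothing measured here accounts for the larger step at this place.

From the compounds shown here alone, only hydrogen and methyl are seen at this place, so it remains open whether a methoxy group, an amine or a longer chain there would give a number nearer compound 1 or compound 4. Also open, going by these compounds, is whether a methyl added at this place on compound 2 would shift its number in the same way.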